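The source may report more compounds than this note shows. Statements on the series, on what has been measured and on what is new or still open speak of the compounds shown alone.

The measured compounds:
compound 1, `COc1ncc(-c2ccc3c(c2)N(c2ccc(C)cc2)C(=O)CO3)cc1NS(=O)(=O)c1ccc(F)cc1`, 22700 nM
compound 2, `COc1ncc(-c2ccc3c(c2)N(C2CCCCC2)C(=O)CO3)cc1NS(=O)(=O)c1ccc(F)cc1`, > 40000 nM
compound 3, `O=C1COc2ccc(-c3cnc(Cl)c(NS(=O)(=O)c4ccc(F)cc4)c3)cc2N1C1CC1`, 12400 nM

All three were tested in a functional assay on HCT-116 cells (Homo sapiens) for antiproliferative activity, read by MTT assay, with a stated time of 72 h; on this read-out lower numbers stand for stronger inhibition and higher numbers for weaker inhibition. The value of compound 2 is a limit of the assay rather than a number (the limit of > 40000 nM in this assay, at which 1 of the 3 values shown sits). Compound 3 has the lowest of the two numbers, and compound 1 stands nearest to it, within the scatter, so no order can be drawn between them.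

Compound 4, `COc1ncc(-c2ccc3c(c2)N(C2CC2)C(=O)CO3)cc1NS(=O)(=O)c1ccc(F)cc1`, has not yet been measured. It differs from compound 3 in one place: methoxy in place of chloro on an aromatic carbon. Among the measured compounds shown here, the only measured step, an at least 1.7-fold higher number from compound 1 to compound 2 (0.24 log units; that floor lies within the scatter), concerns the group on the amide-type nitrogen in a ring and not this change, so nothing measured bears directly on it. The two methoxy compounds, compound 1 and compound 2, give numbers that are no lower than that of compound 3, so no gain is expected; a step within the scatter, a 1.3-fold higher number from compound 3 to compound 4 (0.11 log units; within the scatter), is expected. Compound 4 is therefore estimated at 16000 nM, with a range of 6000 nM to 40000 nM.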

Compound 4, half-maximal inhibitory concentration: 24300 nM
Compound 4: middle estimate off by 1.5-fold (0.18 log units), on the low side; the measured number falls inside the stated range.
By their numbers in this assay, from the lowest: compounds 3, 1 and 4 (each within the scatter of the next). At a limit, above all of these: compound 2.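

In this assay the aromatic carbon next to the ring nitrogen now has a direct reading: methoxy in place of chloro gives a 2.0-fold higher number from compound 3 to compound 4 (0.29 log units; within the scatter), so the two groups cannot be told apart at this position. With methoxy held in place, cyclopropyl in place of 4-methylphenyl on the amide-type nitrogen gives a 1.1-fold higher number from compound 1 to compound 4 (0.03 log units; within the scatter), which sets no order between these two groups either. Cyclopropyl in place of cyclohexyl gives an at least 1.6-fold lower number from compound 2 to compound 4 (0.21 log units; that floor lies within the scatter), but this step starts from a limit of the assay rather than a number: the limit of > 40000 nM in this assay, at which 1 of the 4 values shown sits.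

The compounds shown leave open whether an amine, a nitrile or a longer alkoxy chain such as ethoxy on this aromatic carbon would move the number beyond the scatter. They also leave open whether any such group would behave the same way with another group on the amide-type nitrogen.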